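A few compounds are considered here, and "the series" means these few. Any claim that something is new, unique, unknown or untested is made for them only; others in the source may bear on it.

Compounds measured so far:
compound 1, `Cc1nc(S(C)(=O)=O)ccc1Oc1ncnc(OC2CCN(C(=O)O[C@@H](C)CF)CC2)c1F`, 186 nM
compound 2, `CCC1(OC(=O)N2CCC(Oc3ncnc(Oc4ccc(S(C)(=O)=O)nc4C)c3F)CC2)CC1`, 22 nM
compound 3, `Cc1nc(S(C)(=O)=O)ccc1Oc1ncnc(OC2CCN(C(=S)OC(C)C)CC2)c1F`, 69.9 nM

In a functional assay on isolated protein for inhibition of Glucose-dependent insulinotropic receptor (Homo sapiens), read by HTRF and cAMP accumulation (on this read-out lower numbers stand for an effect already at smaller amounts and higher numbers for an effect only at larger amounts of compound), compound 1 gives 186 nM, the highest of the three numbers. Compound 3 is nearest to it with 69.9 nM, and compound 2 lies furthest away with 22 nM.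

Compound 4, `Cc1nc(S(C)(=O)=O)ccc1Oc1ncnc(OC2CCN(C(=O)C3CCCC3)CC2)c1F`, has not been measured yet. It differs from compound 1 in one place: a group of 5 heavy atoms (5 carbon; one five-membered non-aromatic ring of carbon only) in place of a group of 5 heavy atoms (3 carbon, 1 oxygen, 1 fluorine; no ring), on a carbonyl carbon. The group that leaves carries a fluorine and an oxygen; the cyclopentyl that enters is carbon only and sits on the carbonyl carbon bound to the amide-type nitrogen in the ring.

Within the data shown here, two measured steps bear on this. Both start from compound 1 and alter the group on the amine nitrogen in the ring: an 8.5-fold lower number from compound 1 to compound 2 (0.93 log units; beyond the scatter) and a 2.7-fold lower number from compound 1 to compound 3 (0.43 log units; beyond the scatter). Each change away from the 1-(fluoromethyl)ethyl carbamate of compound 1 gave a lower number in this assay, so a lower number is expected for compound 4 as well, by a modest step, a 3.4-fold lower number from compound 1 to compound 4 (0.53 log units; beyond the scatter).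

Compound 4 is therefore estimated at 55 nM, with a range from 18 nM to 170 nM.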

Compound 4, half-maximal effective concentration: 72.8 nM
Estimate against measurement, compound 4: 1.3-fold (0.12 log units) below; the measured number falls inside the stated range.
By their numbers in this assay, from the lowest: compound 2; then compounds 3 and 4 (each within the scatter of the next); then compound 1.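

In this assay the result gives a first view of this position without any oxygen or fluorine in the group on the carbonyl carbon: with a 2.6-fold lower number from compound 1 to compound 4 (0.41 log units; beyond the scatter), the carbon-only cyclopentyl is compatible with activity here. A different attachment can also give a similar number, since a 1.0-fold higher number from compound 3 to compound 4 (0.02 log units; within the scatter) stays within the scatter, whereas a 3.3-fold higher number from compound 2 to compound 4 (0.52 log units; beyond the scatter) leaves the 1-ethylcyclopropyl carbamate of compound 2 with the lowest number of the set. Nothing measured here explains these differences.

The compounds shown leave open whether the step from compound 1 depends on losing the oxygen, losing the fluorine or gaining the ring. A cyclobutyl, a cyclohexyl or an open-chain pentyl on the same carbonyl carbon would help separate these possibilities.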